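The compounds below may be only part of what the source reports. "The series", "measured", "known", "first", "only" and "open" are said of these compounds alone.

Compound 1 `O=C1Cc2cc(OCCc3ccc(F)cc3)ccc2N1` gives 190000 nM in an assay on cells for inhibition of Amine oxidase [flavin-containing] B (Homo sapiens), read by fluorescence, with stated times of 30 min and 15 min; on this read-out higher numbers stand for weaker inhibition and lower numbers for stronger inhibition. Compound 2 `O=C1Nc2ccc(OCc3cccc(Cl)c3)cc2C1=O` gives 46 nM in this assay. Compound 3 `CC(C)c1ccc(OCCOc2ccc3[nH]c(=O)n(C(C)C)c3c2)cc1` gives 66700 nM in this assay.

Among these three numbers compound 2 stands lowest: compound 3 lies nearest to it and compound 1 furthest, and both gaps lie beyond the scatter. Compound 4 `O=C1Nc2ccc(OCc3ccc(Cl)c(Cl)c3)cc2C1=O` has not yet been measured. It differs from compound 2 by chloro in place of hydrogen on an aromatic carbon. For the measured compounds named here, no pair of measured compounds shares this change, so its size in this assay is not known from the data. The expectation for compound 4 is a step of a 1.5-fold lower number from compound 2 to compound 4 (0.19 log units; within the scatter), small and not clearly beyond the scatter, leaning toward a lower number. Compound 4 is therefore estimated at 30 nM, within a range of 10 nM to 100 nM.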

Compound 4, half-maximal inhibitory concentration: 3 nM
Beside the measured number, compound 4's estimate is 10-fold (1.00 log units) above it; the measured number lies below the stated range.
By their numbers in this assay, from the lowest: compound 4; then compound 2; then compound 3; then compound 1.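

In this assay, chloro in place of hydrogen on an aromatic carbon, ortho to a chloro group and para to a large group, gives a 15-fold lower number from compound 2 to compound 4 (1.19 log units; beyond the scatter), so this change at this position is not neutral. The earlier compounds shown here offered no pair that could size this change; this step is large and lies beyond the scatter. Nothing given here explains its size.

The compounds shown leave open whether a fluoro, methyl or methoxy group at this position would give a similar step. They also leave open whether chloro would give it on the other cores.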